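Naphthylmethyl Sulfanyl Replaces Methylbenzyl Sulfanyl in Compound 1

The compounds below may be only part of what the source reports. "The series", "measured", "known", "first", "only" and "open" are said of these compounds alone.

Compound 1 `Cc1cc(S(=O)(=O)/N=C(\N)N/N=C/C#Cc2ccccc2)c(SCc2ccccc2C)cc1Cl` is the best of three measured compounds in a functional assay on HeLa cells (Homo sapiens) for antiproliferative activity, read by MTT assay, with a stated time of 72 h (a higher number here means a weaker inhibitor, a lower number a stronger inhibitor), where compound 1 gives 19000 nM. Compound 3 `C/C(C#Cc1ccccc1)=N\N/C(N)=N/S(=O)(=O)c1cc(C)c(Cl)cc1SCc1cccc(Cl)c1` gives 21000 nM, and compound 2 `C/C(C#Cc1ccccc1)=N\N/C(N)=N/S(=O)(=O)c1cc(C)c(Cl)cc1SCc1ccccc1C` gives 270000 nM. The step of a 14-fold higher number from compound 1 to compound 2 (1.15 log units; beyond the scatter) is large, as is the step of a 13-fold lower number from compound 2 to compound 3 (1.11 log units; beyond the scatter); the latter changes the group on the saturated chain carbon bound to a sulfur, the same place that is altered here.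

Compound 4 `Cc1cc(S(=O)(=O)/N=C(\N)N/N=C/C#Cc2ccccc2)c(SCc2cccc3ccccc23)cc1Cl` differs from compound 1 by naphthalen-1-yl in place of 2-methylphenyl on a saturated chain carbon bound to a sulfur. For the measured compounds named here, the only measured step at this place, the step from compound 2 to compound 3, shows that an exchange of the aryl group here can move the number strongly, but that exchange was made on a different core and toward a chlorophenyl rather than a naphthyl group, so its direction cannot simply be carried over. A modest step is therefore expected, a 1.6-fold lower number from compound 1 to compound 4 (0.20 log units; within the scatter), with wide uncertainty. Compound 4 is estimated at 12000 nM, in the range 4000 nM to 40000 nM.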

Compound 4, half-maximal inhibitory concentration: 8000 nM
Beside the measured number, compound 4's estimate is 1.5-fold (0.18 log units) above it; the measured number falls inside the stated range.
By their numbers in this assay, from the lowest: compound 4; then compounds 1 and 3 (each within the scatter of the next); then compound 2.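

On the core of compound 1, the group on the saturated chain carbon bound to a sulfur can be enlarged from 2-methylphenyl to naphthalen-1-yl with a gain in this assay: the change gives a 2.4-fold lower number from compound 1 to compound 4 (0.38 log units; beyond the scatter) and so takes the series past the scatter. For the compounds shown here, until now, the only step read at this place was a 13-fold lower number from compound 2 to compound 3 (1.11 log units; beyond the scatter) on the other core, so this is the first lower number at this place on the core of compound 1, although the step is modest rather than large. Nothing shown explains why the number falls with this change.

The compounds shown leave open whether 3-chlorophenyl would give a similar step on the core of compound 1, and whether naphthalen-1-yl would do so on the core of compound 2. They also leave open how naphthalen-2-yl or a pyridine ring would behave at this place.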